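Thiophene for Furan: Cytotoxicity Expected to Hold Steady

The source may hold more compounds than are shown below. What is called first, only, known or untested is meant among the compounds shown, and "the series" means these compounds.

Three compounds share a core in which a six-membered aromatic ring with one nitrogen carries a 3-hydroxyphenyl group, a chlorophenyl group and a third aromatic substituent. For compound 1 `Oc1cccc(-c2cc(-c3ccncc3)nc(-c3cccc(Cl)c3)c2)c1` the entry in an ADME assay on HEK293 cells (Homo sapiens) for cytotoxicity, read by CCK-8 assay and cell counting, with a stated time of 2 days (on this read-out lower numbers stand for stronger inhibition and higher numbers for weaker inhibition), reads "not determined" (no result reported). Compound 2 `Oc1cccc(-c2cc(-c3cccc(Cl)c3)nc(-c3ccco3)c2)c1` gives 2530 nM in this assay, and compound 3 `Oc1cccc(-c2cc(-c3ccc(Cl)cc3)nc(-c3ccco3)c2)c1` gives 8190 nM. Among the two numbers, compound 2 stands lowest; its nearest neighbour is compound 3, reached by the step of a 3.2-fold higher number from compound 2 to compound 3 (0.51 log units; beyond the scatter), which comes from 4-chlorophenyl in place of 3-chlorophenyl on an aromatic carbon.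

Compound 4 `Oc1cccc(-c2cc(-c3cccc(Cl)c3)nc(-c3cccs3)c2)c1` differs from compound 2 in a different place: thiophen-2-yl in place of furan-2-yl on an aromatic carbon. For the measured compounds named here, no measured step touches this position. The only step in hand, a 3.2-fold higher number from compound 2 to compound 3 (0.51 log units; beyond the scatter), concerns the chlorophenyl group and says nothing about the five-membered ring; the exchange of furan-2-yl for thiophen-2-yl has no precedent among these compounds. The two groups match in what is counted, so the expected step from compound 2 to compound 4, a 1.0-fold lower number from compound 2 to compound 4 (0.01 log units; within the scatter), is estimated to stay within the usual scatter, in neither direction. Compound 4 is therefore expected to give about 2500 nM in this assay, with a range from 1000 nM to 6500 nM.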

Compound 4, half-maximal inhibitory concentration: 3150 nM
Estimate against measurement, compound 4: 1.3-fold (0.10 log units) below; the measured number falls inside the stated range.
By their numbers in this assay, from the lowest: compounds 2 and 4 (each within the scatter of the next); then compound 3.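

For the compounds shown here, the step of a 1.2-fold higher number from compound 2 to compound 4 (0.10 log units; within the scatter) gives the first direct reading in this assay at this position, on an aromatic carbon next to the ring nitrogen, and it shows that thiophen-2-yl can stand in place of furan-2-yl without moving the number beyond the scatter. The only earlier step, a 3.2-fold higher number from compound 2 to compound 3 (0.51 log units; beyond the scatter), lies beyond the scatter, so among these compounds the change in the chlorophenyl group registers in this assay, while the exchange of one five-membered aromatic ring for the other does not. No measurement at hand explains why these two groups read alike.

The entry for compound 1, "not determined" (no result reported), allows no comparison at this position, so any steps involving that compound cannot be read, and the reading here rests on furan-2-yl and thiophen-2-yl alone. As far as these compounds go, it remains open whether an amine, a carboxylic acid or a longer chain at this position would stay as close to compound 2, and whether thiophen-2-yl would behave the same way alongside a 4-chlorophenyl group.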